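The compounds below may be only part of what the source reports. "The series", "measured", "known", "first", "only" and "open" are said of these compounds alone.

Working notes on the series. Of the compounds shown here, three have been measured in a functional assay on PC-3 cells (Homo sapiens) for inhibition, read by MTT assay, with a stated time of 24 h; on this read-out higher numbers stand for weaker inhibition and lower numbers for stronger inhibition. Compound 1 `Fc1ccc(-c2cc(/C=N/c3ccccc3)on2)cc1` gives 36500 nM in this assay. Among the compounds with values here, compound 2 `FC(F)(F)c1ccc(-c2cc(/C=N/c3ccccc3)on2)cc1` gives 35700 nM in this assay, and the only one-point step measured, trifluoromethyl in place of fluoro on an aromatic carbon, is a 1.0-fold lower number from compound 1 to compound 2 (0.01 log units; within the scatter). Compound 3 `CCc1cc2ccccc2nc1-c1cc(-c2ccccc2)no1` stands apart from these two: in this assay compound 3 reaches only a limit, > 100000 nM, and no number is known for it. Within the data shown here, this is the limit noted as the limit of > 100000 nM in this assay, at which 1 of the 3 values shown sits, at which one of the three values sits, so compound 3 is the one compound of the set for which only a limit is known.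

The next step goes from compound 3 to compound 4 `CCCc1cc2ccccc2nc1-c1cc(-c2ccccc2)no1`. The change is methyl in place of hydrogen on a saturated chain carbon, two bonds along the chain from an aromatic carbon; cut one bond further out it reads methyl to ethyl, ethyl to propyl. Among the measured compounds shown here, no measured step matches this change: the one step known, from compound 1 to compound 2, concerns an aromatic substituent on a different core and was within the scatter. For the measured compounds named here, nothing among the measured compounds therefore supports a step beyond the scatter here. For compound 4 the expected step is a step that the limit leaves unreadable from compound 3 to compound 4, that is, none beyond the scatter. Compound 4 is accordingly estimated at 150000 nM in this assay, with a range from 50000 nM to 500000 nM, and most likely reported only as a limit again.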

Compound 4, half-maximal inhibitory concentration: 51300 nM
Compound 4: the middle estimate sits 2.9-fold (0.47 log units) above what was measured; measured number inside the range.
By their numbers in this assay, from the lowest: compounds 2, 1 and 4 (each within the scatter of the next). At a limit, above all of these: compound 3.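

In this assay, within the data shown here, compound 4 gives 51300 nM, the one number so far on the core it shares with compound 3. The ethyl to propyl change, methyl in place of hydrogen on a saturated chain carbon, two bonds along the chain from an aromatic carbon, is read as an at least 1.9-fold lower number from compound 3 to compound 4 (0.28 log units; that floor lies within the scatter); this is only a floor on the step, so whether the full step at this position goes beyond the scatter stays unsettled. Compound 3 stands only at a limit, > 100000 nM, and the reading of the step rests on that limit: the limit of > 100000 nM in this assay, at which 1 of the 4 values shown sits.

The compounds shown leave open whether a longer chain, such as butyl, would carry the direction of this single step any further on this core or would end it. They also leave open how an amine or a carboxylic acid in place of the entering methyl would read in this assay, so one step on one chain remains the whole of what is known about this position.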